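The compounds below may be only part of what the source reports. "The series", "measured", "known", "first", "only" and "open" are said of these compounds alone.

Of the compounds shown here, three built on a shared core have been tested in a functional assay on OVCAR-4 cells (Homo sapiens) for inhibition, read by sulforhodamine B assay, with a stated time of 48 h; a lower number here means that less compound is tolerated, a higher number that more compound is tolerated. Compound 1 `CCOC(=O)[C@H](CCC(=O)O)NC(=O)c1ccc(Sc2nc3cc(N)cc(N)c3nc2-c2ccccc2)cc1` gives < 100000 nM, which is a limit of the assay rather than a number. Compound 3 `CCOC(=O)[C@H](CCC(=O)O)NC(=O)c1ccc(Oc2nc3cc(N)cc(N)c3nc2-c2ccccc2)cc1` gives < 100000 nM, again a limit. Compound 2 `Nc1cc(N)c2nc(-c3ccccc3)c(Sc3ccc(F)cc3)nc2c1` gives < 100000 nM, also a limit, so it sits with the other two at the limit of < 100000 nM in this assay, at which 3 of the 3 values shown sit, and none of the three is set apart. Compound 4 `Nc1cc(N)c2nc(-c3ccccc3)c(NCc3ccc(F)cc3)nc2c1` carries (4-fluorobenzyl)amino in place of (4-fluorophenyl)sulfanyl on an aromatic carbon. With only limits to go by, no step beyond the usual scatter is expected in this assay in either direction. Compound 4 is accordingly estimated at 30000 nM, within a range of 5000 nM to 100000 nM. The step that the limit leaves unreadable from compound 2 to compound 4 expected here is small, and a limit may well be reported again.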

Compound 4, concentration lethal to 50% of the cells: 60300 nM
Compound 4: middle estimate off by 2.0-fold (0.30 log units), on the low side, within the range that was stated.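

Compound 2 stands only at a limit, so no step from it to compound 4 can be read in this assay: the limit of < 100000 nM in this assay, at which 3 of the 4 values shown sit.

Still open, on these data alone, is how far (4-fluorobenzyl)amino and (4-fluorophenyl)sulfanyl really differ on the shared core.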